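Nitro in place of bromo: expectation for compound 3

A few compounds are considered here, and "the series" means these few. Any claim that something is new, unique, unknown or untested is made for them only; others in the source may bear on it.

Measured so far:
compound 1 `CC(C)=CCC1Cc2c(OCCCNS(=O)(=O)c3ccc([N+](=O)[O-])cc3)cc(=O)n(CCCO)c2CC1(C)C`: 17.3%
compound 2 `CC(C)=CCC/C(C)=C/CC1Cc2c(OCCCNS(=O)(=O)c3ccc(Br)cc3)cc(=O)n(CCCO)c2CC1(C)C`: 0%

In a functional assay on PANC-1 cells (Homo sapiens) for inhibition, read by MTT assay, with a stated time of 24 h, tested at 10 uM (on this read-out lower numbers stand for less inhibition and higher numbers for more inhibition at the one concentration tested (going by the name of the read-out)), compound 1 gives 17.3% and compound 2 gives 0%. Compound 2 stands lowest of the two numbers, and compound 1 lies higher by a gap beyond the scatter. Compound 3 `CC(C)=CCC/C(C)=C/CC1Cc2c(OCCCNS(=O)(=O)c3ccc([N+](=O)[O-])cc3)cc(=O)n(CCCO)c2CC1(C)C` differs from compound 2 by nitro in place of bromo on an aromatic carbon. Going by the values given here, no single-change step between measured compounds is known, since compound 1 also carries a different chain. A small upward step a number 10 percentage points higher from compound 2 to compound 3 (within the scatter) is expected for compound 3, because compound 1, which carries nitro, gives 17.3%. Compound 3 is estimated at 10%, within 0% to 25%.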

Compound 3, a percentage reported as inhibition, at one concentration (the size of the read-out at that concentration, not a potency): 0%
For compound 3 the middle estimate is 10 percentage points above the measured one; low and high end bracket the measured number.
By their numbers in this assay, from the lowest: compounds 2 and 3 (each within the scatter of the next); then compound 1.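

In this assay, nitro in place of bromo on an aromatic carbon, para to a large group, gives no change at the digits printed from compound 2 to compound 3 (within the scatter), so this change does not separate the two compounds at this position. With nitro held constant, 3-methylbut-2-en-1-yl in place of hydrogen on a saturated chain carbon gives a number 17.3 percentage points lower from compound 1 to compound 3 (beyond the scatter), so among these steps only the chain change lies beyond the scatter. Nothing available bears on the reason for either result. Open, as far as these compounds go, is how an amine or a carboxylic acid on that aromatic carbon would read in this assay, on either chain.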